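Methyl on the imidazole carbon: a second test of a silent change

The source may hold more compounds than are shown below. What is called first, only, known or untested is meant among the compounds shown, and "the series" means these compounds.

Compound 1 `CC(=O)NCC#CCn1ccnc1`, compound 2 `CC(=O)NCC#CCn1cncc1C` and compound 3 `Cn1ccn(CC#CCn2ccnc2)c1=O` have been run in a functional assay on the whole organism for antagonist activity, with Mus musculus as the target; on this read-out lower numbers stand for an effect already at smaller amounts and higher numbers for an effect only at larger amounts of compound. Compound 1 returned only a limit of the assay, > 100 mg/kg. Compound 2 likewise returned only a limit, > 100 mg/kg. Compound 3 also stands at a limit, > 100 mg/kg. Going by the values given here, the one single-point comparison is methyl in place of hydrogen on an aromatic carbon, for which the two limits give a step that the two limits leave unreadable from compound 1 to compound 2. Among the compounds with values here, all three values rest on (the limit of > 100 mg/kg in this assay, at which 3 of the 3 values shown sit), so no step in the measured set can be read.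

Compound 4 `Cc1cncn1CC#CCn1ccn(C)c1=O` is not yet measured; it differs from compound 3 by methyl in place of hydrogen on an aromatic carbon. This is the same kind of change as from compound 1 to compound 2, though the surroundings are not described in identical words: in one case the neighbouring ring atom bears a group of 8 heavy atoms, in the other a large group. The difference between the two cores, compound 1 against compound 3, is not broken down here.

For compound 4 in this assay the expected step is a step that the limit leaves unreadable from compound 3 to compound 4, resting on compound 3 sitting at > 100 mg/kg and on the unreadable step from compound 1 to compound 2. Compound 4 is therefore estimated at 150 mg/kg, most likely again reported only as a limit.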

Compound 4, dose for half-maximal effect: > 100 mg/kg
Compound 4: a limit, no number; the forecaster's own chance of this, stated with the estimate: 85%; the middle value lies beyond the limit too.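

No step can be read from compound 3 to compound 4 in this assay, so the methyl in place of hydrogen stays without a size here too, and the reason is the same for the whole set: the limit of > 100 mg/kg in this assay, at which 4 of the 4 values shown sit.

The compounds shown leave open whether the methyl change, or either core, gives any measurable effect in this assay at all.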